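A few compounds are considered here, and "the series" means these few. Any claim that something is new, unique, unknown or untested is made for them only; others in the source may bear on it.

Compound 1 `CCOC(=O)c1cn(C[C@H]2O[C@@H](n3ccc(=O)[nH]c3=O)[C@H](SCC)[C@@H]2SCC)nn1` bears an ethoxycarbonyl group on an aromatic carbon of the shared core. In a functional assay on A549 cells (Homo sapiens) for cytotoxicity, read by MTT assay, with a stated time of 72 h (on this read-out lower numbers stand for an effect already at smaller amounts and higher numbers for an effect only at larger amounts of compound), compound 1 gives >= 100000 nM, which is a limit of the assay rather than a number. Compound 2 `CCS[C@@H]1[C@H](SCC)[C@@H](Cn2cc(-c3cccs3)nn2)O[C@H]1n1ccc(=O)[nH]c1=O` differs from compound 1 by thiophen-2-yl in place of ethoxycarbonyl on an aromatic carbon. In this assay compound 2 gives >= 100000 nM, again a limit. Compound 3 `CCOC(=O)c1cn(C[C@H]2O[C@@H](n3cc(C)c(=O)[nH]c3=O)[C@H](SCC)[C@@H]2SCC)nn1` differs from compound 1 by methyl in place of hydrogen on an aromatic carbon. In this assay compound 3 gives >= 100000 nM, also a limit. Because all three values sit at the limit of >= 100000 nM in this assay, at which 3 of the 3 values shown sit, the step that the two limits leave unreadable from compound 1 to compound 2 and the step that the two limits leave unreadable from compound 1 to compound 3 cannot be sized. Compound 4 `CCS[C@@H]1[C@H](SCC)[C@@H](Cn2cc(-c3cccs3)nn2)O[C@H]1n1cc(C)c(=O)[nH]c1=O` is not yet measured; it differs from compound 3 by thiophen-2-yl in place of ethoxycarbonyl on an aromatic carbon, the same change that turns compound 1 into compound 2, made at the same place, while the two cores differ as described for compound 3 against compound 1. The expected step of a number no higher from compound 3 to compound 4 (the limit leaves the size open) rests on compound 1 and compound 2 both sitting at the limit of >= 100000 nM in this assay, at which 3 of the 3 values shown sit. Compound 4 is therefore estimated at 100000 nM, within a range from 50000 nM to 300000 nM, most likely reported again only as a limit.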

Compound 4, half-maximal effective concentration: 37300 nM
For compound 4 the middle estimate is 2.7-fold (0.43 log units) above the measured one; the whole stated range lies above it.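

In this assay, thiophen-2-yl in place of ethoxycarbonyl on the core that carries the methyl gives an at least 2.6-fold lower number from compound 3 to compound 4 (0.42 log units; beyond the scatter). The starting value is a limit, so the real step could be larger. Seen from the other side, methyl in place of hydrogen with thiophen-2-yl already present gives an at least 2.6-fold lower number from compound 2 to compound 4 (0.42 log units; beyond the scatter), so among the four compounds shown, only the one with both changes has a measured number rather than a limit. This does not show whether the change carries from one core to another, because the same swap on the core without the methyl and the methyl step between the two ethoxycarbonyl compounds both join two limits and cannot be read: the limit of >= 100000 nM in this assay, at which 3 of the 4 values shown sit.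

As far as these compounds go, only ethoxycarbonyl and thiophen-2-yl appear at this place on the ring, so it stays open how a phenyl ring, an amine or a carboxylic acid would behave there. From the compounds shown here alone, it also stays open whether a longer chain in place of the methyl would move the number further in either direction.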